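Series notes: from compound 3 to compound 4

This account rests on a few compounds, and the source may have more. Where it says the series, first, only, none or still open, it means among the compounds named here.

Measured in a functional assay on A549 cells (Homo sapiens) for cytotoxicity, read by MTT assay, with a stated time of 72 h; a lower number here means a stronger inhibitor, a higher number a weaker inhibitor:
- compound 1 `Cc1cc(=O)n(-c2ccc(Br)cc2F)nc1C(=O)Nc1ccc(Oc2ncnc3ccsc23)c(F)c1`: 2980 nM
- compound 2 `Cc1cc(=O)n(-c2ccc(F)cc2)nc1C(=O)Nc1ccc(Oc2ncnc3ccsc23)c(F)c1`: 580 nM
- compound 3 `Cc1cc(=O)n(-c2ccc(F)c(F)c2)nc1C(=O)Nc1ccc(Oc2ncnc3ccsc23)c(F)c1`: 4590 nM

Compound 3 gives the highest of the three numbers. Its nearest neighbour is compound 1, with a 1.5-fold higher number from compound 1 to compound 3 (0.19 log units; within the scatter); its furthest is compound 2, with a 7.9-fold higher number from compound 2 to compound 3 (0.90 log units; beyond the scatter). The remaining measured step, a 5.1-fold lower number from compound 1 to compound 2 (0.71 log units; beyond the scatter), likewise concerns only the aryl group on the aromatic nitrogen.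

Compound 4 `Cc1cc(=O)n(-c2ccc(F)c(F)c2)nc1C(=O)Nc1ccc(Oc2ncnc3sccc23)c(F)c1` keeps that aryl group and differs from compound 3 by a group of 9 heavy atoms (6 carbon, 2 nitrogen, 1 sulfur; one five-membered aromatic ring with 1 hetero atom, one six-membered aromatic ring with 2 hetero atoms) in place of a group of 9 heavy atoms (6 carbon, 2 nitrogen, 1 sulfur; one five-membered aromatic ring with 1 hetero atom, one six-membered aromatic ring with 2 hetero atoms), on an oxygen on an aromatic ring; the two compounds have the same atoms, joined differently. Going by the values given here, none of the three measured steps touches this part of the molecule, so no measured step bears on the change, and there is no basis in the data for expecting a step in either direction beyond the scatter. The range given is kept wide for that reason.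

Compound 4 is therefore estimated at 4600 nM in this assay, with a range of 1200 nM to 18000 nM, meaning an expected 1.0-fold higher number from compound 3 to compound 4 (0.00 log units; within the scatter).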

Compound 4, half-maximal inhibitory concentration: 15700 nM
Estimate against measurement, compound 4: 3.4-fold (0.53 log units) below; measured number inside the range.
By their numbers in this assay, from the lowest: compound 2; then compounds 1 and 3 (each within the scatter of the next); then compound 4.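

In this assay, the group on an oxygen on an aromatic ring proves to be a second place in the series where a change registers, with a 3.4-fold higher number from compound 3 to compound 4 (0.53 log units; beyond the scatter) on an exchange that leaves the aryl group on the aromatic nitrogen untouched. The group that leaves and the group that enters have the same atoms, the same ring types and the same counts of hydrogen-bond donors and acceptors, so a difference in how those atoms are joined is enough to give a step beyond the scatter. No measurement to hand accounts for this step.

Going by these compounds alone, the exchange is seen with only one aryl group on the aromatic nitrogen, so whether it gives a similar step with the 4-fluorophenyl group of compound 2 stays open. Also open, from the compounds shown here alone, is how a pyridine ring or an amine-bearing group on this oxygen would read in this assay against the two groups seen here.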